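The source may report more compounds than this note shows. Statements on the series, on what has been measured and on what is new or still open speak of the compounds shown alone.

All four compounds share one core and differ only in the group carried on a saturated chain carbon bound to an amine nitrogen in a ring. Within the data shown here, compound 1 `CN(C)CCN1CCN(c2nc(-c3ccccn3)nc3c2CN(Cc2ccccc2)CC3)CC1` is the one that gives a number: in an assay on A549 cells with Cystic fibrosis transmembrane conductance regulator variant F508del (Homo sapiens) as the target, read by fluorescence, with a stated time of 25 min (on this read-out higher numbers stand for larger maximal responses and lower numbers for smaller maximal responses), compound 1 gives 57%. Compound 2 `COc1ccc(CN2CCc3nc(-c4ccccn4)nc(N4CCN(CCN(C)C)CC4)c3C2)cc1` gives no number, for in this assay compound 2 gives "not active" (no number reported). Compound 3 `CN(C)CCN1CCN(c2nc(-c3ccccn3)nc3c2CN(Cc2ccsc2)CC3)CC1` is the same: in this assay compound 3 gives "not active" (no number reported), so compound 3 stands without a single number, and compound 2 is the one further entry without one.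

Compound 4 `CC(C)c1ccc(CN2CCc3nc(-c4ccccn4)nc(N4CCN(CCN(C)C)CC4)c3C2)cc1` has not been measured. Going from compound 3 to compound 4 the change is 4-isopropylphenyl in place of thiophen-3-yl on a saturated chain carbon bound to an amine nitrogen in a ring; cut one bond further out, it reads (thiophen-3-yl)methyl to 4-isopropylbenzyl. Whether this brings back a measurable response is open, since compound 1 is the only one of the three measured that gives one, and a no-number outcome remains likely. For compound 4 in this assay a step toward a modest measurable response is expected, and the estimated value is 25%, in a range from 0% to 55%.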

Compound 4, largest response reached (Emax), in percent of the reference or control that the assay uses: "not active" (no number reported)
Compound 4 has no reported number here; the estimate stays without a comparison.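

In this assay compound 3 and compound 4 both give no number, so no step can be read between them. Nothing shown here bears on this result. The compounds shown leave open why, of the groups compared, only compound 1 gives a measurable response.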